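Removing One Chloro from a Dichlorophenyl Adenosine Ligand

The source may report more compounds than this note shows. Statements on the series, on what has been measured and on what is new or still open speak of the compounds shown alone.

Of the compounds shown here, two have so far been tested in an assay on cells for displacement of a labelled ligand from adenosine receptor A2b (Homo sapiens), read by scintillation counting and radioligand binding, with a stated time of 30 min, tested at 10 uM; on this read-out lower numbers stand for less inhibition and higher numbers for more inhibition at the one concentration tested (going by the name of the read-out). Compound 1 `Cn1cnc2c(N3CCCCC3)nc(-c3ccccc3O)nc21` gives 30.2% in this assay. Compound 2 `CN1CCN(c2nc(-c3ccc(Cl)c(Cl)c3)nc3[nH]cnc23)CC1` gives 24.1%; on the numbers alone this stands at the bottom of the two, but the gap to compound 1 lies within the usual scatter of the method, so the two compounds cannot be told apart. Compound 3 `CN1CCN(c2nc(-c3cccc(Cl)c3)nc3[nH]cnc23)CC1` has not yet been measured. It differs from compound 2 in one place: hydrogen in place of chloro on an aromatic carbon. Going by the values given here, no pair of measured compounds differing in a single place is available, so the size of such a step cannot be read from the data. The loss of a chloro group is a small change, and compound 3 is expected to stay close to compound 2, with at most a modest drop. Compound 3 is estimated to give 20%, with a likely range from 5% to 38%, which amounts to an expected step of a number 4.1 percentage points lower from compound 2 to compound 3 (within the scatter).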

Compound 3, a percentage reported as inhibition, at one concentration (the size of the read-out at that concentration, not a potency): 29.9%
Beside the measured number, compound 3's estimate is 9.9 percentage points below it; the measured number falls inside the stated range.
By their numbers in this assay, from the lowest: compounds 2, 3 and 1 (each within the scatter of the next).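

Going by these compounds alone, this is the first pair here that differs in only one place, so the size of a change at this position can now be read. In this assay, going from 3,4-dichlorophenyl to 3-chlorophenyl gives a number 5.8 percentage points higher from compound 2 to compound 3 (within the scatter), so removing this chloro group, para to a large group, makes no difference that this read-out can detect. No measurement at hand offers an explanation for this result.

As far as these compounds go, it remains open whether a different group on this same aromatic carbon, such as a methoxy group, an amine or a carboxylic acid, would shift the number by more than the scatter. Also open, from the compounds shown here alone, is what the remaining chloro group contributes, a question that a plain phenyl group in its place could answer.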